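Notes on the step from compound 3 to compound 4

A few compounds are considered here, and "the series" means these few. Any claim that something is new, unique, unknown or untested is made for them only; others in the source may bear on it.

Measured so far in a functional assay on P388 cells (Mus musculus) for inhibition; a lower number here means a stronger inhibitor, a higher number a weaker inhibitor:
- compound 1 `O=C1CCCCC/C1=C\c1ccccc1`: > 50000 nM (a limit)
- compound 2 `O=C1CCCCC/C1=C\c1cccc(F)c1`: > 50000 nM (a limit)
- compound 3 `O=C1CCCCC/C1=C\c1cccc(Br)c1`: 24100 nM (a number)

In this assay, among the compounds with values here, compound 3 gives 24100 nM as the only actual number. Compound 1 and compound 2 both stand at the limit of > 50000 nM in this assay, at which 2 of the 3 values shown sit, and so give no number.

The change to compound 4 `COc1cccc(/C=C2\CCCCCC2=O)c1` is methoxy in place of bromo on an aromatic carbon and amounts to methoxy in place of bromo on an aromatic carbon. Within the data shown here, no methoxy compound has been measured, so the evidence is indirect. Two measured steps lead to bromo: an at least 2.0-fold lower number from compound 1 to compound 3 (0.31 log units; beyond the scatter) with bromo in place of hydrogen, and an at least 2.0-fold lower number from compound 2 to compound 3 (0.31 log units; beyond the scatter) with bromo in place of fluoro. Both are bounds and not sizes. The remaining step, a step that the two limits leave unreadable from compound 1 to compound 2 with fluoro in place of hydrogen, gives no size.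

Removing bromo has so far meant losing a readable number, as compound 1 and compound 2 show when set against compound 3 at 24100 nM in this series. A modest move towards a higher number is therefore expected, with a 1.7-fold higher number from compound 3 to compound 4 (0.22 log units; within the scatter) as the estimated step in this assay and no certainty that it clears the scatter. A result reported only as a limit is quite possible. For compound 4 the expected value is 40000 nM with an estimated range from 18000 nM to 90000 nM in this assay for now.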

Compound 4, half-maximal inhibitory concentration: 50000 nM
Compound 4: middle estimate off by 1.3-fold (0.10 log units), on the low side; the measured number falls inside the stated range.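

In this assay, within the data shown here, methoxy in place of bromo at this position gives a 2.1-fold higher number from compound 3 to compound 4 (0.32 log units; beyond the scatter), the first step at this position with a readable size, as the earlier steps to compound 3 were bounds only. This step also sets two groups at this position against each other on actual numbers, with bromo giving the lower number of the two and the gap lying beyond the scatter. The remaining steps are a number no higher from compound 2 to compound 4 (the limit leaves the size open) and a number no higher from compound 1 to compound 4 (the limit leaves the size open). Neither size can be read, because compound 1 and compound 2 each stand at a limit and not a number: the limit of > 50000 nM in this assay, at which 2 of the 4 values shown sit.

Going by these compounds, with only bromo and methoxy giving numbers, two points do not make a trend, and it stays open where a chloro, a trifluoromethyl, an amine or a carboxylic acid at this position would fall relative to compound 3 and compound 4. On these data alone, it is equally open whether the order of bromo and methoxy holds at another aromatic carbon of the shared core, or on a core with a changed carbonyl.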